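A few compounds are considered here, and "the series" means these few. Any claim that something is new, unique, unknown or untested is made for them only; others in the source may bear on it.

- Compound 1 `CCCCN1CCC[C@H]1CNC(=O)c1cc(S(N)(=O)=O)ccc1OC`: 49.2 mg/kg
- Compound 2 `CCN1CCC[C@H]1CNC(=O)c1cc(S(N)(=O)=O)cc2c1O[C@@H](C)C2`: 5.7 mg/kg

In a functional assay on the whole organism with Mus musculus as the target (a lower number here means that less compound is needed, a higher number that more compound is needed for the effect), compound 2 gives the lower of the two numbers, 5.7 mg/kg, and so needs clearly less compound than compound 1 at 49.2 mg/kg. Compound 3 `CCN1CCC[C@@H]1CNC(=O)c1cc(S(N)(=O)=O)cc2c1O[C@@H](C)C2` has the same atoms and bonds as compound 2, and the difference lies only in how one centre is drawn: the two compounds have the same atoms and bonds and differ only in configuration as drawn: 1 of 2 stereo elements differ; a stereocentre at a saturated ring carbon is drawn S in compound 2 and R in compound 3. For the measured compounds named here, compounds 1 and 2 are both drawn S at this ring carbon, so no measurement yet shows what the R form does. Even so, a change beyond the scatter towards a higher number is expected, though its size is uncertain. The expected change is a 7.0-fold higher number from compound 2 to compound 3 (0.85 log units; beyond the scatter). For compound 3, the estimated value is 40 mg/kg, within a range of 10 mg/kg to 160 mg/kg.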

Compound 3, dose for half-maximal effect: 71.7 mg/kg
For compound 3 the middle estimate is 1.8-fold (0.25 log units) below the measured one; the range from low to high includes it.
By their numbers in this assay, from the lowest: compound 2; then compounds 1 and 3 (each within the scatter of the next).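

In this assay, inverting the saturated ring carbon from S to R gives a 13-fold higher number from compound 2 to compound 3 (1.10 log units; beyond the scatter), so the S form needs clearly less compound in this pair. The step can be placed on that single centre because nothing else changes: the fact that compounds 2 and 3 differ only in the configuration as drawn. Compounds 1 and 2 are both drawn S there, so they could not show how much this centre matters.

Going by these compounds, whether the S form keeps its advantage when a benzyl group replaces the ethyl group remains open. On these data alone, the role of the second stereocentre is also open, as compound 2 and compound 3 share its configuration.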